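The source may hold more compounds than are shown below. What is called first, only, known or untested is meant among the compounds shown, and "the series" means these compounds.

In a functional assay on A549 cells (Homo sapiens) for inhibition, read by MTT assay, with a stated time of 48 h (on this read-out lower numbers stand for stronger inhibition and higher numbers for weaker inhibition), three amides on a shared core have been measured: compound 1 (`CCNC(=O)/C=C/c1c(/C=C/c2ccc(OC)cc2)cc(OC)cc1OC`) gives 7860 nM, compound 2 (`COc1ccc(/C=C/c2cc(OC)cc(OC)c2/C=C/C(=O)N2CCCCC2C)cc1`) gives 5770 nM and compound 3 (`COc1ccc(/C=C/c2cc(OC)cc(OC)c2/C=C/C(=O)Nc2cc(OC)c(OC)c(OC)c2)cc1`) gives 5140 nM. Compound 3 thus stands within the scatter of both others. Compound 4 (`COc1ccc(/C=C/c2cc(OC)cc(OC)c2/C=C/C(=O)NC(C)C)cc1`) differs from compound 3 in one place: isopropyl in place of 3,4,5-trimethoxyphenyl on an amide-type nitrogen, with isopropyl in place of 3,4,5-trimethoxyphenyl on an amide-type nitrogen. Going by the values given here, two measured steps bear on this change, a 1.4-fold lower number from compound 1 to compound 2 (0.13 log units; within the scatter) and a 1.5-fold lower number from compound 1 to compound 3 (0.18 log units; within the scatter), and both lie within the scatter. No step beyond the scatter is therefore expected, in either direction. The estimated step is a 1.3-fold higher number from compound 3 to compound 4 (0.10 log units; within the scatter). Compound 4 is expected at 6500 nM, with an estimated range of 3500 nM to 12000 nM.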

Compound 4, half-maximal inhibitory concentration: 2360 nM
Beside the measured number, compound 4's estimate is 2.8-fold (0.44 log units) above it; measured number below the stated range.
By their numbers in this assay, from the lowest: compound 4; then compounds 3, 2 and 1 (each within the scatter of the next).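

In this assay, the group on the amide-type nitrogen now shifts the number beyond the scatter: isopropyl in place of 3,4,5-trimethoxyphenyl gives a 2.2-fold lower number from compound 3 to compound 4 (0.34 log units; beyond the scatter) and isopropylamino in place of 2-methylpiperidin-1-yl on the carbonyl carbon gives a 2.4-fold lower number from compound 2 to compound 4 (0.39 log units; beyond the scatter) at this place. Methyl in place of hydrogen on the saturated chain carbon bound to that nitrogen gives a 3.3-fold lower number from compound 1 to compound 4 (0.52 log units; beyond the scatter) as well, so even this one added methyl moves the number beyond the scatter. Nothing available explains these steps. Going by these compounds, whether a tert-butyl or cyclopropyl group on that nitrogen would give a lower number remains open, as does the effect of a longer chain bearing an amine.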